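The compounds below may be only part of what the source reports. "The series", "measured", "known", "first", "only" and "open" are said of these compounds alone.

Measured so far in a functional assay on MCF7 cells (Homo sapiens) for antiproliferative activity, read by sulforhodamine B assay, with a stated time of 48 h; a higher number here means a weaker inhibitor, a lower number a stronger inhibitor:
compound 1 `O=C(CCCCCCN1C(=O)/C(=N\O)c2cc(Br)ccc21)NO`: 1770 nM
compound 2 `Cc1ccc2c(c1)/C(=N/O)C(=O)N2CCCCCCC(=O)NO`: 1190 nM
compound 3 `CO/N=C1/C(=O)N(CCCCCCC(=O)NO)c2ccc(Br)cc21`: 7790 nM

Compound 2 is obtained from compound 1 by methyl in place of bromo on an aromatic carbon; this change gave a 1.5-fold lower number from compound 1 to compound 2 (0.17 log units; within the scatter). Compound 3 carries a different core; how it differs from the core of compound 1 is not broken down here. Compound 3 shows the highest of the three numbers, beyond the scatter from both compound 1 and compound 2.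

Compound 4 `CO/N=C1/C(=O)N(CCCCCCC(=O)NO)c2ccc(C)cc21` is not yet measured. It is obtained from compound 3 by methyl in place of bromo on an aromatic carbon, the same change as that from compound 1 to compound 2, at the same place. Because the earlier step gave a 1.5-fold lower number from compound 1 to compound 2 (0.17 log units; within the scatter), a step of similar small size is expected here: a 1.4-fold lower number from compound 3 to compound 4 (0.15 log units; within the scatter). In this assay compound 4 is therefore expected to give about 5500 nM, most likely between 2500 nM and 12000 nM.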

Compound 4, half-maximal inhibitory concentration: 16700 nM
For compound 4 the middle estimate is 3.0-fold (0.48 log units) below the measured one; the measured number lies above the stated range.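

In this assay, methyl in place of bromo gave a 2.1-fold higher number from compound 3 to compound 4 (0.33 log units; beyond the scatter) and so did not carry over unchanged from the core of compound 1 to the core of compound 3. The steps on the two cores differ: the same change on two cores in this assay, a 1.5-fold lower number (0.17 log units; within the scatter) from compound 1 to compound 2 and a 2.1-fold higher number (0.33 log units; beyond the scatter) from compound 3 to compound 4, 3.2-fold (0.50 log units) apart, beyond the scatter of two such steps. With one pair per core, this shows only that the outcome of the change depends on the core among these four compounds; it does not show which feature of the cores is responsible or what would happen on any other core.

Open, as far as these compounds go, is whether a chloro or methoxy group on that aromatic carbon would follow the step on the core of compound 1 or the step on the core of compound 3. Also open, from the compounds shown here alone, is whether a shorter or longer chain to the hydroxamic acid would alter the gap between the two steps.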